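Moving the Bromine on the Benzyl Arm

The source may hold more compounds than are shown below. What is called first, only, known or untested is meant among the compounds shown, and "the series" means these compounds.

Compound 1 `CCN(Cc1ccc(Br)cc1)c1ccc(C(=O)N2CCc3ccc(OS(N)(=O)=O)cc3C2)cc1` stands lowest of the two compounds measured in a physicochemical assay for lipophilicity (on this read-out higher numbers stand for higher lipophilicity and lower numbers for lower lipophilicity), where compound 1 gives 1.93. Its nearest neighbour, compound 2 `NS(=O)(=O)Oc1ccc2c(c1)CN(C(=O)c1ccc(N3CCC(Cc4ccccc4)CC3)cc1)CC2`, gives 3.87 in this assay, a number beyond the scatter above compound 1; the two are not joined by a change in a single place, so their values can only be set side by side. Compound 3 `CCN(Cc1cccc(Br)c1)c1ccc(C(=O)N2CCc3ccc(OS(N)(=O)=O)cc3C2)cc1` has not yet been measured in this assay. It differs from compound 1 in one place: 3-bromophenyl in place of 4-bromophenyl on a saturated chain carbon bound to a nitrogen on an aromatic ring. The same atoms are joined differently, so nothing is added or taken away. Going by the values given here, no measured step of this kind is available to draw on, so in this assay the expected step is no change at the digits printed from compound 1 to compound 3 (within the scatter), a change no larger than the scatter. The value for compound 3 in this assay is therefore estimated at 1.93, with a range from 1.6 to 2.3.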

Compound 3, partition coefficient: 1.93
For compound 3 middle estimate and measured number coincide at the digits printed, within the range that was stated.
By their numbers in this assay, from the lowest: compounds 1 and 3 (each within the scatter of the next); then compound 2.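

The exchange of 4-bromophenyl for 3-bromophenyl, on a saturated chain carbon bound to a nitrogen on an aromatic ring, gives in this assay a step of no change at the digits printed from compound 1 to compound 3 (within the scatter). Going by these compounds alone, this is the first step here that joins two measured compounds differing in one place, and it shows that this read-out does not separate the two bromophenyl groups at this position on the shared core. No measured evidence bearing on this result is available.

The compounds shown leave open how this assay would read if an amine or a carboxylic acid stood on the phenyl ring in place of the bromine. They also leave open whether the same exchange would again give no separation with a longer chain in place of the ethyl.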